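Acetoxy to hydroxy: from compound 2 to compound 4

This account rests on a few compounds, and the source may have more. Where it says the series, first, only, none or still open, it means among the compounds named here.

In a functional assay on HT-29 cells (Homo sapiens) for inhibition (on this read-out higher numbers stand for weaker inhibition and lower numbers for stronger inhibition), compound 2 `CC(=O)Oc1c(I)c(O)c2c(=O)cc(-c3ccccc3)oc2c1I` gives 3000 nM. Compound 3 `CC(=O)Oc1c(C(F)(F)F)c(O)c2c(=O)cc(-c3ccccc3)oc2c1C(F)(F)F` gives 2900 nM, and compound 1 `COc1cc(OC)c2c(=O)cc(-c3ccccc3)oc2c1I` gives 2600 nM. Compound 2 therefore stands level with both others, as all three values lie within the scatter of one another. No two of these compounds differ in one place only, so the series offers no measured step as a guide.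

Compound 4 `O=c1cc(-c2ccccc2)oc2c(I)c(O)c(I)c(O)c12` differs from compound 2 by a single change hydrogen in place of acetyl on an oxygen on an aromatic ring, or acetoxy to hydroxy. The data hold no direct test of this change. With compound 2 at 3000 nM and the three measured values so close, no step beyond the scatter is expected in this assay, in either direction. The expected change is a 1.2-fold lower number from compound 2 to compound 4 (0.08 log units; within the scatter). For compound 4 the estimated value is 2500 nM, with an expected range of 800 nM to 7000 nM.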

Compound 4, half-maximal inhibitory concentration: 4400 nM
For compound 4 the middle estimate is 1.8-fold (0.25 log units) below the measured one; low and high end bracket the measured number.
By their numbers in this assay, from the lowest: compounds 1, 3, 2 and 4 (each within the scatter of the next).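

In this assay, going by these compounds alone, hydrogen in place of acetyl on an oxygen on an aromatic ring gives a 1.5-fold higher number from compound 2 to compound 4 (0.17 log units; within the scatter) and is the first one-place step available. On the core with the iodo groups, this position therefore carries either acetoxy or hydroxy with no difference beyond the scatter, so the acetyl is not needed to keep the read-out in this range. No independent measurement bears on this result.

As far as these compounds go, whether acetoxy to hydroxy gives a similar step with the trifluoromethyl groups of compound 3 remains open. Also open, from the compounds shown here alone, is how the read-out responds to a longer acyl chain such as butanoyl on this oxygen, or to an amine in place of the oxygen.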